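Taking one methoxy off compound 3

A few compounds are considered here, and "the series" means these few. Any claim that something is new, unique, unknown or untested is made for them only; others in the source may bear on it.

Going by the values given here, in a functional assay on MCF7 cells (Homo sapiens) for antiproliferative activity, read by MTT assay, with a stated time of 48 h (a higher number here means a weaker inhibitor, a lower number a stronger inhibitor), compound 3 (`COc1ccc(-c2nn(-c3ccccc3)cc2C(Nc2nc3ccc(OC)cc3s2)c2c(O)ccc3ccccc23)cc1`) gives 41800 nM, the highest of the three numbers so far. Compound 1 (`COc1ccc(-c2nn(-c3ccccc3)cc2C(Nc2nc3ccccc3s2)c2c(O)ccc3ccccc23)cc1`) gives 17500 nM, and compound 2 (`COc1ccc2nc(NC(c3cn(-c4ccccc4)nc3-c3ccc(F)cc3)c3c(O)ccc4ccccc34)sc2c1`) gives 16900 nM. Compound 4 (`COc1ccc2nc(NC(c3cn(-c4ccccc4)nc3-c3ccccc3)c3c(O)ccc4ccccc34)sc2c1`) has hydrogen in place of methoxy on an aromatic carbon, para to a large group, so 4-methoxyphenyl becomes phenyl (hydrogen in place of methoxy on an aromatic carbon). The closest evidence is a 2.5-fold higher number from compound 2 to compound 3 (0.39 log units; beyond the scatter), a modest step that puts methoxy in place of fluoro at this same place. Also modest is a 2.4-fold higher number from compound 1 to compound 3 (0.38 log units; beyond the scatter), where methoxy replaces hydrogen elsewhere on the molecule. The expected change is therefore modest and toward a stronger inhibitor, a 2.1-fold lower number from compound 3 to compound 4 (0.32 log units; beyond the scatter). Compound 4 is estimated at 20000 nM, with an expected range of 9000 nM to 42000 nM.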

Compound 4, half-maximal inhibitory concentration: 40800 nM
Compound 4: the middle estimate sits 2.0-fold (0.31 log units) below what was measured; measured number inside the range.
By their numbers in this assay, from the lowest: compounds 2 and 1 (each within the scatter of the next); then compounds 4 and 3 (each within the scatter of the next).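

In this assay, taking the methoxy off at this place, so that 4-methoxyphenyl becomes phenyl, makes no readable difference (a 1.0-fold lower number from compound 3 to compound 4 (0.01 log units; within the scatter)). Fluoro is the substituent that stands apart here, since replacing it with hydrogen also gives a weaker result (a 2.4-fold higher number from compound 2 to compound 4 (0.38 log units; beyond the scatter)), so the earlier fluoro-to-methoxy step reflects the loss of fluoro, not the arrival of methoxy. No measurement here explains why fluoro differs. On these data alone, whether chloro or an amine at this place would behave like fluoro or like hydrogen remains open. So does whether fluoro has the same effect with no methoxy on the other end of the molecule.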